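The compounds below may be only part of what the source reports. "The series", "measured", "known", "first", "only" and "open" are said of these compounds alone.

Compound 1 `COc1ccc2nc(C)cc(OCc3ccc4ccccc4n3)c2c1`: 31600 nM
Compound 2 `COc1ccc2nc(C)c(NC(=O)C(=O)Nc3cc(C)cc(C)c3)c(O)c2c1`: > 100000 nM
Compound 3 `COc1ccc2nc(C)cc(OCC(=O)NCc3cc(C)cc(C)c3)c2c1`: > 100000 nM

In a toxicity assay on HepG2 cells (Homo sapiens) for inhibition, read by CellTiter-Glo, with a stated time of 48 h (a lower number here means a stronger inhibitor, a higher number a weaker inhibitor), compound 1 gives 31600 nM. Compound 2 reaches only the limit of the assay, > 100000 nM. Compound 3 also reaches only the limit, > 100000 nM. Compound 3 thus stands at the limit of > 100000 nM in this assay, at which 2 of the 3 values shown sit; it is not separated from compound 2, and both sit beyond compound 1.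

Compound 4 `COc1ccc2nc(C)cc(OCC(=O)Nc3nc(C)c(C)s3)c2c1` differs from compound 3 in one place: 4,5-dimethyl-1,3-thiazol-2-yl in place of 3,5-dimethylbenzyl on an amide-type nitrogen. Among the compounds with values here, no measured pair shows the effect of such a change, so there is no step to lean on. With compound 3 at the limit, the estimated step of an at least 1.2-fold lower number from compound 3 to compound 4 (0.09 log units; that floor lies within the scatter) is none beyond the scatter. Compound 4 is therefore expected to give about 80000 nM, within 20000 nM to 200000 nM, and may well return only a limit again.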

Compound 4, half-maximal inhibitory concentration: > 100000 nM
Compound 4: a limit, no number; the forecaster's own chance of this, stated with the estimate: 60%; at least 1.2-fold (0.09 log units) between middle value and limit.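

In this assay compound 4, like compound 3, returns only a limit, so no step between the two can be read: the limit of > 100000 nM in this assay, at which 3 of the 4 values shown sit.

As far as these compounds go, what 4,5-dimethyl-1,3-thiazol-2-yl in place of 3,5-dimethylbenzyl does to the number remains open.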